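Widening the sulfur substituent: notes toward compound 4

The source may report more compounds than this note shows. Statements on the series, on what has been measured and on what is new or still open speak of the compounds shown alone.

Compound 3 `CSc1cc(C)c(C(=O)N=C(N)N)cc1S(C)(=O)=O` gives 6 nM in a functional assay for inhibition of sodium/hydrogen exchanger (Oryctolagus cuniculus) (on this read-out higher numbers stand for weaker inhibition and lower numbers for stronger inhibition), and holds the lowest of the three measured numbers. Compound 1 `CCC(C)c1cc(C)c(C(=O)N=C(N)N)cc1S(C)(=O)=O` gives 8 nM in this assay, and the step of a 1.3-fold lower number from compound 1 to compound 3 (0.12 log units; within the scatter) lies within the scatter, so no order between these two can be claimed. Within the data shown here, compound 2 `Cc1cc(-c2ccccc2)c(S(C)(=O)=O)cc1C(=O)N=C(N)N` gives 19 nM in this assay; the step of a 3.2-fold lower number from compound 2 to compound 3 (0.50 log units; beyond the scatter) is the only separation of compound 3 from another measured compound that is beyond the scatter.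

Compound 4 `Cc1cc(Sc2ccc(Cl)cc2)c(S(C)(=O)=O)cc1C(=O)N=C(N)N` differs from compound 3 by 4-chlorophenyl in place of methyl on a sulfur. Among the measured compounds shown here, two measured steps bear on this: a 2.4-fold higher number from compound 1 to compound 2 (0.38 log units; beyond the scatter) and a 3.2-fold lower number from compound 2 to compound 3 (0.50 log units; beyond the scatter), both showing a higher number where the phenyl stands on the aromatic carbon. For the measured compounds named here, no measured step swaps a group on the sulfur itself, so the parallel is loose. A modest step toward a higher number is therefore expected, a 2.5-fold higher number from compound 3 to compound 4 (0.40 log units; beyond the scatter). Compound 4 is estimated at 15 nM in this assay, with a range from 5 nM to 45 nM.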

Compound 4, half-maximal inhibitory concentration: 19 nM
For compound 4 the middle estimate is 1.3-fold (0.10 log units) below the measured one; the measured number falls inside the stated range.
By their numbers in this assay, from the lowest: compounds 3 and 1 (each within the scatter of the next); then compounds 2 and 4 (each within the scatter of the next).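

In this assay the sulfur accepts a much larger substituent than methyl at modest cost, with 4-chlorophenyl in place of methyl giving a 3.2-fold higher number from compound 3 to compound 4 (0.50 log units; beyond the scatter) as the whole penalty. Against phenyl on the aromatic carbon the result is no change at the digits printed from compound 2 to compound 4 (within the scatter) and against sec-butyl it is a 2.4-fold higher number from compound 1 to compound 4 (0.38 log units; beyond the scatter) in this set, so the two groups carrying an aromatic ring fall together on the higher side, with methylsulfanyl and sec-butyl on the lower. No supporting data accompany these numbers to account for the separation.

What the chlorine contributes and what the sulfur link contributes both remain open, as no pair shown isolates either one. Also open, from the compounds shown here alone, is how an amine or a carboxylic acid on the phenyl ring, or a longer alkyl chain on the sulfur, would read.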